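A few compounds are considered here, and "the series" means these few. Any claim that something is new, unique, unknown or untested is made for them only; others in the source may bear on it.

Measured so far in an in vivo ADME assay on the whole organism (strain Sprague-Dawley) for pharmacokinetics, with Rattus norvegicus as the target; on this read-out lower numbers stand for slow clearance and higher numbers for fast clearance:
compound 1 `CCCCCOC(=O)N1CCN(C(=O)[C@H](CCC(=O)O)NC(=O)c2cc(N3CCC(C(=O)N4CCCC4)CC3)nc(-c3ccccc3)n2)CC1` gives 2 mL/min/kg
compound 2 `CCCCCOC(=O)N1CCN(C(=O)[C@H](CCC(=O)O)NC(=O)c2cc(N3CCC(CNC)CC3)nc(-c3ccccc3)n2)CC1` gives 31 mL/min/kg

Within the data shown here, compound 2 holds the higher of the two numbers; the only measured step, a 16-fold higher number from compound 1 to compound 2 (1.19 log units; beyond the scatter), separates it from compound 1. Compound 3 `CCCCCOC(=O)N1CCN(C(=O)[C@H](CCC(=O)O)NC(=O)c2cc(N3CCC(C(N)=O)CC3)nc(-c3ccccc3)n2)CC1` is not yet measured. It differs from compound 2 by carbamoyl in place of (methylamino)methyl on a saturated ring carbon. Among the measured compounds shown here, the one step that bears on this is a 16-fold higher number from compound 1 to compound 2 (1.19 log units; beyond the scatter), which shows that exchanging a carbonyl-bearing group for (methylamino)methyl at this ring carbon went with a large rise in this assay. The reverse exchange, back toward a carbonyl-bearing group, is therefore expected to give a step of a 7.8-fold lower number from compound 2 to compound 3 (0.89 log units; beyond the scatter), downward. Compound 3 is estimated at 4 mL/min/kg, with a range of 1.5 mL/min/kg to 12 mL/min/kg.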

Compound 3, clearance: 68 mL/min/kg
For compound 3 the middle estimate is 17-fold (1.23 log units) below the measured one, outside the stated range (above it).
By their numbers in this assay, from the lowest: compound 1; then compound 2; then compound 3.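

In this assay a carbonyl at this ring carbon does not by itself go with a low number: the step of a 2.2-fold higher number from compound 2 to compound 3 (0.34 log units; beyond the scatter) runs upward, not downward. The low number of compound 1 instead depends on what the carbonyl carries, since amino in place of pyrrolidin-1-yl on the carbonyl carbon gives a 34-fold higher number from compound 1 to compound 3 (1.53 log units; beyond the scatter) on an otherwise unchanged structure. No evidence on hand explains either step.

Still open, from the compounds shown here alone, is whether the low number needs the pyrrolidine ring itself or only a substituted amide nitrogen. A methylamide, a dimethylamide or a piperidine amide at this ring carbon would help separate these.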